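Series notes: carbamoyl chain trimming at the indole amide

This account rests on a few compounds, and the source may have more. Where it says the series, first, only, none or still open, it means among the compounds named here.

Measured so far, in an assay for inhibition of serine/threonine-protein kinase PLK2 (Homo sapiens), read by FRET and Z'-LYTE, with a stated time of 1 h; on this read-out higher numbers stand for weaker inhibition and lower numbers for stronger inhibition:
- compound 1, `CCCNS(=O)(=O)c1ccc(Nc2ncc3c(n2)N(c2ccn(C)n2)C(CC)C(=O)N3C)cc1`: 190 nM
- compound 2, `CCC1C(=O)N(C)c2cnc(-n3ccc4cc(C(=O)NC(C)C)ccc43)nc2N1c1ccn(C)n1`: 125 nM
- compound 3, `CC[C@@H]1C(=O)N(C)c2cnc(-n3ccc4cc(C(=O)NCC(C)C)ccc43)nc2N1C1CCCC1`: 18.6 nM

Compound 3 gives the lowest number of the three; the nearest, compound 2, sits beyond the scatter above it, and compound 1 sits further still. Among the measured compounds shown here, none of the three pairs differs in one place only, so no single-change step is available for comparison, and the gaps above are read as gaps between values, nothing more.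

The next compound, compound 4, `CC[C@@H]1C(=O)N(C)c2cnc(-n3ccc4cc(C(=O)NC)ccc43)nc2N1C1CCCC1`, is compound 3 with one change: hydrogen in place of isopropyl on a saturated chain carbon bound to an amide-type nitrogen. The difference thus concerns only the carbamoyl substituent, from isobutylcarbamoyl to methylcarbamoyl, on the same core and with the cyclopentyl retained.

For the measured compounds named here, no measured pair shows what this shortening does here. The expectation is a moderate weakening, an increase from compound 3 to compound 4 of a 2.4-fold higher number from compound 3 to compound 4 (0.38 log units; beyond the scatter) in this assay, not far outside the scatter. Compound 4 is therefore estimated at 45 nM, within a range of 15 nM to 140 nM.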

Compound 4, half-maximal inhibitory concentration: 8.6 nM
Compound 4: middle estimate off by 5.2-fold (0.72 log units), on the high side; the whole stated range lies above it.
By their numbers in this assay, from the lowest: compound 4; then compound 3; then compounds 2 and 1 (each within the scatter of the next).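

In this assay, among the compounds shown here, trimming isobutylcarbamoyl to methylcarbamoyl gives a 2.2-fold lower number from compound 3 to compound 4 (0.34 log units; beyond the scatter), a modest step but beyond the scatter and the first single-change reading. With the shared core and the cyclopentyl held constant, the isopropyl on the saturated chain carbon bound to an amide-type nitrogen is not required for a low number at this position, and removing it does not weaken inhibition. Nothing at hand bears on why the number falls with this change.

From the compounds shown here alone, whether the same shortening would act alike on the core of compound 2, which lacks the cyclopentyl, stays open. Also open, going by these compounds, is what an ethylcarbamoyl, a primary carboxamide or a chain ending in an amine would give at this carbamoyl position.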